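Piperidine for piperazine on the amine side chain: cytotoxicity

A few compounds are considered here, and "the series" means these few. Any claim that something is new, unique, unknown or untested is made for them only; others in the source may bear on it.

Measured so far in an ADME assay on Huh-7 cells (Homo sapiens) for cytotoxicity; on this read-out higher numbers stand for lower toxicity in this test and lower numbers for higher toxicity in this test:
compound 1, `CN1CCN(CCCNCc2cn(-c3ccc([N+](=O)[O-])cc3)nc2-c2ccc(Cl)cc2)CC1`, gives 3700 nM;
compound 2, `CN1CCN(CCCNCc2cn(-c3ccc(C(F)(F)F)cc3)nc2-c2ccc(OC(F)(F)F)cc2)CC1`, gives 2300 nM;
compound 3, `CCCN1CCC(CNCc2cn(-c3ccc([N+](=O)[O-])cc3)nc2-c2ccc(Cl)cc2)CC1`, gives 11000 nM.

Compounds 1 and 2 share the same side chain on different cores; the difference between the two cores is not broken down here. From compound 1 to compound 3 the change is 1-propylpiperidin-4-yl in place of 2-(4-methylpiperazin-1-yl)ethyl on a saturated chain carbon bound to an amine nitrogen, and in this assay it gave a 3.0-fold higher number from compound 1 to compound 3 (0.47 log units; beyond the scatter).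

Compound 4, `CCCN1CCC(CNCc2cn(-c3ccc(C(F)(F)F)cc3)nc2-c2ccc(OC(F)(F)F)cc2)CC1`, is not yet measured. It differs from compound 2 by 1-propylpiperidin-4-yl in place of 2-(4-methylpiperazin-1-yl)ethyl on a saturated chain carbon bound to an amine nitrogen, the same change at the same place as between compound 1 and compound 3. Among the measured compounds shown here, because compound 2 gives 2300 nM and the one earlier instance of this change gave a 3.0-fold higher number from compound 1 to compound 3 (0.47 log units; beyond the scatter), a step of similar size is expected, about a 3.0-fold higher number from compound 2 to compound 4 (0.48 log units; beyond the scatter). Compound 4 is therefore estimated at 6900 nM, with a range from 3000 nM to 15000 nM; the expectation rests on a single prior step.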

Compound 4, half-maximal cytotoxic concentration: 2200 nM
Beside the measured number, compound 4's estimate is 3.1-fold (0.50 log units) above it, outside the stated range (below it).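

In this assay, the exchange of 2-(4-methylpiperazin-1-yl)ethyl for 1-propylpiperidin-4-yl gives a 1.0-fold lower number from compound 2 to compound 4 (0.02 log units; within the scatter), so on this core the two numbers stand within the scatter. The step does not carry over unchanged from one core to the other: the same change on two cores in this assay, a 3.0-fold higher number (0.47 log units; beyond the scatter) from compound 1 to compound 3 and a 1.0-fold lower number (0.02 log units; within the scatter) from compound 2 to compound 4, 3.1-fold (0.49 log units) apart, beyond the scatter of two such steps. This single pair of steps shows that the result of the change can depend on the core, but it does not show which difference between the cores matters, as nitro and chloro are exchanged for trifluoromethyl and trifluoromethoxy together.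

Open, as far as these compounds go, is whether a core pairing nitro with trifluoromethoxy, or trifluoromethyl with chloro, would follow either step. Also open, from the compounds shown here alone, is how a core bearing a nitrile in place of nitro would respond to the same change.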